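Working notes: from compound 2 to compound 3

The compounds below may be only part of what the source reports. "The series", "measured", "known", "first", "only" and "open" are said of these compounds alone.

- compound 1 (`COc1ccc(-n2cc(COc3ccc(/C=C/C(=O)c4cc5c(cc4O)OC(C)(C)CC5)cc3)nn2)c([N+](=O)[O-])c1`) gives "not active" (no number reported)
- compound 2 (`Cc1c(-n2cc(COc3ccc(/C=C/C(=O)c4ccc5c(c4O)CCC(C)(C)O5)cc3)nn2)cccc1[N+](=O)[O-]`) gives 73500 nM

Within the data shown here, in a functional assay on IMR-32 cells (Homo sapiens) for antiproliferative activity, read by MTT assay (a higher number here means a weaker inhibitor, a lower number a stronger inhibitor), compound 2 at 73500 nM carries the only number, while compound 1 has none. Compound 3 (`Cc1ccc(-n2cc(COc3ccc(/C=C/C(=O)c4ccc5c(c4O)CCC(C)(C)O5)cc3)nn2)cc1Br`) differs from compound 2 by 3-bromo-4-methylphenyl in place of 2-methyl-3-nitrophenyl on an aromatic nitrogen in the group on an aromatic nitrogen. No measured step sizes this change, so no shift beyond the scatter in this assay is expected, and neither direction is favoured. The expected size is a 1.2-fold lower number from compound 2 to compound 3 (0.09 log units; within the scatter) on this estimate. Compound 3 is estimated at 60000 nM with an expected range of 15000 nM to 200000 nM in this read-out.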

Compound 3, half-maximal inhibitory concentration: "not active" (no number reported)
Nothing numeric was reported for compound 3; no gap can be computed for the estimate.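

In this assay, among these compounds, compound 3 carries no number, so no step from compound 2 to compound 3 can be read. No measurement shown bears on this result. On these data alone, how far 3-bromo-4-methylphenyl in place of 2-methyl-3-nitrophenyl shifts the read-out stays open.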